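A few compounds are considered here, and "the series" means these few. Any claim that something is new, unique, unknown or untested is made for them only; others in the source may bear on it.

Going by the values given here, in a functional assay on CEM-SS cells (Homo sapiens) for cytotoxicity (on this read-out higher numbers stand for lower toxicity in this test and lower numbers for higher toxicity in this test), only two compounds have been measured so far. Compound 1 (`CCCCCCCCCCCCCC(=O)NC(CO[C@@H]1O[C@H](CO)[C@H](O)[C@H](O)[C@H]1O)C(=O)NCCOS(=O)(=O)O`) gives > 100000 nM, which is a limit of the assay and not a number. Compound 2 (`NC(CO[C@@H]1O[C@H](CO)[C@H](O)[C@H](O)[C@H]1O)C(=O)NCCCCCCCCCCCC(=O)O`) gives > 100000 nM, which is also a limit. That leaves compound 1 with no number of its own, only (the limit of > 100000 nM in this assay, at which 2 of the 2 values shown sit).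

The next compound to be tested is compound 3 (`CCCCCCCCCCCCCC(=O)NC(CO[C@@H]1O[C@H](CO)[C@H](O)[C@H](O)[C@H]1O)C(=O)NCCO`), which differs from compound 1 in one place: hydrogen in place of sulfo on an oxygen on a saturated carbon. Hydrogen takes the place of sulfo on an oxygen on a saturated carbon, turning 2-(sulfooxy)ethyl into 2-hydroxyethyl. Among the compounds with values here, no step between measured compounds is available to size this change, so the expectation rests on the limit alone. The expected a number no higher from compound 1 to compound 3 (the limit leaves the size open) is no larger than the scatter in this assay, and any step that does appear is expected to run toward lower numbers, that is, higher toxicity in this test. Compound 3 is estimated at 100000 nM, with an expected range from 30000 nM to 300000 nM.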

Compound 3, half-maximal cytotoxic concentration: > 100000 nM
Compound 3: only a limit was reported (the forecaster's own chance of this, stated with the estimate: 70%); the middle value lies on the limit itself.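

In this assay compound 3 gives > 100000 nM, which is a limit of the assay and not a number. Going by these compounds alone, compound 1 also stands at a limit, so no step between compound 1 and compound 3 can be read. The compounds shown leave open whether hydrogen in place of sulfo changes this read-out at all, and they offer only one reference point: the limit of > 100000 nM in this assay, at which 3 of the 3 values shown sit.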